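Swapping 3-methoxyphenyl for 3,5-dimethylphenyl in a toxicity test

The compounds below may be only part of what the source reports. "The series", "measured", "known", "first", "only" and "open" are said of these compounds alone.

Compound 1 `Oc1cc(C(F)(F)F)ccc1-c1nc(-c2ccccc2O)n(-c2cccc(C(F)(F)F)c2)n1`: 49700 nM
Compound 2 `COc1cccc(-n2nc(-c3ccc(C(F)(F)F)cc3O)nc2-c2ccccc2O)c1`: 56400 nM

In a toxicity assay on PC-12 cells (Rattus norvegicus) for cytotoxicity, read by MTT assay (on this read-out lower numbers stand for stronger inhibition and higher numbers for weaker inhibition), compound 2 gives 56400 nM and compound 1 gives 49700 nM, so the two values lie within the scatter of each other. Compound 3 `Cc1cc(C)cc(-n2nc(-c3ccc(C(F)(F)F)cc3O)nc2-c2ccccc2O)c1` differs from compound 2 in one place: 3,5-dimethylphenyl in place of 3-methoxyphenyl on an aromatic nitrogen. In words, it carries 3,5-dimethylphenyl in place of 3-methoxyphenyl on an aromatic nitrogen. Among the compounds with values here, only one measured step bears on this change: a 1.1-fold higher number from compound 1 to compound 2 (0.05 log units; within the scatter), with methoxy in place of trifluoromethyl on an aromatic carbon. That single step stays within the scatter, so it offers no ground for expecting a real shift in either direction in this assay. The expected step is a 1.1-fold lower number from compound 2 to compound 3 (0.03 log units; within the scatter), which is no change beyond the scatter. Compound 3 is estimated at 53000 nM, with an expected range of 27000 nM to 100000 nM.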

Compound 3, half-maximal inhibitory concentration: 263000 nM
The estimate for compound 3 lay 5.0-fold (0.70 log units) below the measured number; measured number above the stated range.
By their numbers in this assay, from the lowest: compounds 1 and 2 (each within the scatter of the next); then compound 3.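

At this aromatic nitrogen, the aryl group does make a difference in this assay: 3,5-dimethylphenyl in place of 3-methoxyphenyl gives a 4.7-fold higher number from compound 2 to compound 3 (0.67 log units; beyond the scatter) here, and in place of 3-(trifluoromethyl)phenyl it gives a 5.3-fold higher number from compound 1 to compound 3 (0.72 log units; beyond the scatter) here. The earlier step (a 1.1-fold higher number from compound 1 to compound 2 (0.05 log units; within the scatter)) had shown no real difference, so compound 3 is the first of these compounds to stand apart, on the side of weaker inhibition. The entering group has the same 8 heavy atoms as 3-methoxyphenyl, but 0 hydrogen-bond acceptors rather than 1. No measurement here speaks to the reason for the shift. As far as these compounds go, it remains open whether the shift follows the pair of methyl groups or the loss of the earlier substituents. From the compounds shown here alone, whether a plain phenyl or a 3-aminophenyl group on this nitrogen would fall with compounds 1 and 2 or with compound 3 also remains open.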